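The compounds below may be only part of what the source reports. "The series", "measured", "known", "first", "only" and "open" are said of these compounds alone.

Compound 1, with the structure `C=C1[C@@H](O)[C@H](n2cnc3c(N)nc(N)nc32)O[C@@H]1CO`, and compound 2, with the structure `C=C1[C@@H](O)[C@H](n2cnc3c(N)ncnc32)O[C@@H]1CO`, share one core and differ in a single place: hydrogen in place of amino on an aromatic carbon. In a functional assay on L1210 cells (Mus musculus) for inhibition (on this read-out higher numbers stand for weaker inhibition and lower numbers for stronger inhibition), compound 1 gives only a limit of the assay, > 200000 nM, and no number. In this assay compound 2 gives 228000 nM. Between these two the change makes a step that the limit leaves unreadable from compound 1 to compound 2, and the size of this step stays hidden because of the limit of > 200000 nM in this assay, at which 1 of the 3 values shown sits.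

Compound 3, with the structure `C=C1[C@H](n2cnc3c(N)nc(N)nc32)O[C@H](CO)[C@H]1O`, is built from the same atoms as compound 1, joined differently; the difference between the two cores is not broken down here. In this assay compound 3 gives 8200 nM, the lowest of the two numbers at hand, and the gap to compound 2 lies beyond the usual scatter.

Compound 4, with the structure `C=C1[C@H](n2cnc3c(N)ncnc32)O[C@H](CO)[C@H]1O`, has not yet been measured. Relative to compound 3 it carries hydrogen in place of amino on an aromatic carbon, the same change as the one from compound 1 to compound 2, at a place described in the same words. The earlier step gives no readable size, so nothing from it says whether this change helps or hurts. The expected step from compound 3 to compound 4 is therefore a small one, a 1.5-fold higher number from compound 3 to compound 4 (0.17 log units; within the scatter), resting only on the absence of a readable direction. Compound 4 is expected to give about 12000 nM, estimated to fall between 2500 nM and 60000 nM.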

Compound 4, half-maximal inhibitory concentration: 65000 nM
Compound 4: middle estimate off by 5.4-fold (0.73 log units), on the low side; the measured number lies above the stated range.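

On the core of compound 3, replacing the amino group with hydrogen weakens inhibition in this assay, with a 7.9-fold higher number from compound 3 to compound 4 (0.90 log units; beyond the scatter), a modest step that lies beyond the usual scatter. The same change on the core of compound 1 cannot be read in size, because compound 1 gives only a limit of the assay and no number: the limit of > 200000 nM in this assay, at which 1 of the 4 values shown sits. The pair of compound 3 and compound 4 therefore shows what this change does on one core, but it does not show that the change carries over from one core to the other with the same size, or even in the same direction.

The compounds shown hold only amino or hydrogen on the aromatic carbon between two ring nitrogen atoms, so it remains open how a methylamino group, a hydroxyl group or a chlorine atom at that place would read on either core. As far as these compounds go, it also remains open whether the amino group would matter to a similar degree on further cores, and a number for the core of compound 1 with the amino group in place would be needed before the two steps could be set side by side.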